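Chloro for fluoro in a series at the assay limit

The compounds below may be only part of what the source reports. "The series", "measured", "known", "first", "only" and "open" are said of these compounds alone.

In a functional assay on 4T1 cells (Homo sapiens) for cytotoxicity, read by MTT assay, with a stated time of 48 h (on this read-out higher numbers stand for weaker inhibition and lower numbers for stronger inhibition), compound 1 `CCn1c(/C=C2/C(=O)Nc3ccc(F)cc32)nc2ccccc21` gives > 50000 nM as a limit and not a number. Compound 2 `Cn1c(/C=C2/C(=O)Nc3ccc([N+](=O)[O-])cc32)nc2ccccc21` gives > 50000 nM as a limit too. Compound 1 therefore stands at the limit of > 50000 nM in this assay, at which 2 of the 2 values shown sit, and offers no number to step from. Compound 3 `CCn1c(/C=C2/C(=O)Nc3ccc(Cl)cc32)nc2ccccc21` has chloro in place of fluoro on an aromatic carbon, counted as chloro in place of fluoro on an aromatic carbon with the rest of the core of compound 1 unchanged. The estimate is a number no higher from compound 1 to compound 3 (the limit leaves the size open) in this assay and is expected to stay within the scatter with no favoured direction. Compound 3 is estimated at 50000 nM with an expected range from 20000 nM to 100000 nM and a limit reading is also likely.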

Compound 3, half-maximal inhibitory concentration: > 50000 nM
Compound 3: a limit, no number; the forecaster's own chance of this, stated with the estimate: 75%; the middle value lies on the limit itself.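

No new step can be read from compound 1 to compound 3 in this assay, as both readings are limits and not numbers: the limit of > 50000 nM in this assay, at which 3 of the 3 values shown sit.

The compounds shown leave open whether chloro or fluoro on the shared core differ at all in this read-out.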